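The source may hold more compounds than are shown below. What is called first, only, known or untested is meant among the compounds shown, and "the series" means these compounds.

Working notes on the series, measured in a functional assay on PC-3 cells (Homo sapiens) for antiproliferative activity, read by MTT assay, with a stated time of 72 h; on this read-out lower numbers stand for stronger inhibition and higher numbers for weaker inhibition:

- compound 1 `CCCC(=O)NNC(=O)c1csc2ncc(-c3ccc(C)cc3)n12`: 53500 nM
- compound 2 `COc1ccc(-c2cnc3scc(C(=O)NNC(C)=O)n23)cc1`: 28300 nM
- compound 3 `CCC(=O)NNC(=O)c1csc2ncc(-c3ccc(OC)cc3)n12`: 79800 nM

Compound 3, at 79800 nM, lies within the scatter of compound 1, at 53500 nM. The number for compound 2, at 28300 nM, is lower than both.

Next in line is compound 4 `CCCC(=O)NNC(=O)c1csc2ncc(-c3ccc(OC)cc3)n12`, not yet measured. methyl in place of hydrogen on a saturated chain carbon, two bonds along the chain from a carbonyl carbon This is methyl in place of hydrogen on a saturated chain carbon, two bonds along the chain from a carbonyl carbon, so propanoyl becomes propylcarbonyl.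

Among the compounds with values here, only one measured step is of a similar kind: a 2.8-fold higher number from compound 2 to compound 3 (0.45 log units; beyond the scatter). Within the data shown here, there the methyl stands on a saturated chain carbon bound to a carbonyl carbon, so the place differs, and no step has been measured at the place now in question. That single modest step gives only weak guidance on direction, so no change beyond the scatter is expected in this assay.

The expected step is a 1.1-fold lower number from compound 3 to compound 4 (0.03 log units; within the scatter). For compound 4 the estimated value is 75000 nM, with an expected range of 35000 nM to 150000 nM.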

Compound 4, half-maximal inhibitory concentration: 66400 nM
Beside the measured number, compound 4's estimate is 1.1-fold (0.05 log units) above it; low and high end bracket the measured number.
By their numbers in this assay, from the lowest: compounds 2, 1, 4 and 3 (each within the scatter of the next, the first and the last beyond it).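

In this assay, propanoyl to propylcarbonyl gives a 1.2-fold lower number from compound 3 to compound 4 (0.08 log units; within the scatter) and so shows that methyl on a saturated chain carbon, two bonds along the chain from a carbonyl carbon, leaves the number within the scatter. Ethyl in place of hydrogen on the saturated chain carbon bound to a carbonyl carbon gives a 2.3-fold higher number from compound 2 to compound 4 (0.37 log units; beyond the scatter), while methyl at that place gives a 2.8-fold higher number from compound 2 to compound 3 (0.45 log units; beyond the scatter), so among these compounds the step beyond the scatter is already present with methyl. With the propylcarbonyl chain in place, methoxy in place of methyl on an aromatic carbon gives a 1.2-fold higher number from compound 1 to compound 4 (0.09 log units; within the scatter) and also stays within the scatter.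

On these data alone, whether a longer chain, a benzoyl group or an amine on the chain would stay in this range remains open. Nothing at hand gives a reason for these steps.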